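A few compounds are considered here, and "the series" means these few. Any claim that something is new, unique, unknown or untested is made for them only; others in the source may bear on it.

The compounds measured so far, in an assay on 1321N1 cells for antagonist activity at P2Y purinoceptor 6 (Homo sapiens), read by FLIPR and calcium flux; a lower number here means a stronger inhibitor, a higher number a weaker inhibitor:

Compound 1 `O=[N+]([O-])C1=Cc2cccc(Cl)c2OC1C(F)(F)F` — 3690 nM
Compound 2 `O=[N+]([O-])C1=Cc2cc(C#Cc3ccc(CO)cc3)ccc2OC1C(F)(F)F` — 2000 nM
Compound 3 `O=[N+]([O-])C1=Cc2c(Cl)cccc2OC1C(F)(F)F` — 15700 nM

Among these three, compound 2 carries the lowest number in this assay, but compound 1 sits within the usual scatter of it, so the two cannot be ranked against each other; compound 3 lies beyond the scatter and gives the highest number of the set. Compound 4 `COC(=O)c1ccc(C#Cc2ccc3c(c2)C=C([N+](=O)[O-])C(C(F)(F)F)O3)cc1` has not yet been measured. It differs from compound 2 in one place: methoxycarbonyl in place of hydroxymethyl on an aromatic carbon. Among the measured compounds shown here, no measured pair shows what this kind of change does in this assay, so the expectation rests on compound 2 alone. The step from compound 2 to compound 4 is expected to be no change at the digits printed from compound 2 to compound 4 (within the scatter), not beyond the scatter in either direction. Compound 4 is therefore estimated at 2000 nM, with a range from 800 nM to 5000 nM.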

Compound 4, half-maximal inhibitory concentration: 3970 nM
Compound 4: the middle estimate sits 2.0-fold (0.30 log units) below what was measured; measured number inside the range.
By their numbers in this assay, from the lowest: compounds 2, 1 and 4 (each within the scatter of the next); then compound 3.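

In this assay, methoxycarbonyl in place of hydroxymethyl on this aromatic carbon, para to a large group, gives a 2.0-fold higher number from compound 2 to compound 4 (0.30 log units; within the scatter). This pair shows that the position accepts the larger group, which has no hydrogen-bond donor, without a readable change in the number. Nothing available explains why the two groups read alike.

From the compounds shown here alone, it remains open whether a carboxylic acid or an amine at this position would also stay within the scatter. Going by these compounds, it is equally open whether a bare hydrogen there would do so.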